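Fluoro for Hydrogen on Two Unreadable Cores

A few compounds are considered here, and "the series" means these few. Any claim that something is new, unique, unknown or untested is made for them only; others in the source may bear on it.

Compound 1 `Cc1cn(C/C=C\CNC(=O)c2ccccc2)c(=O)[nH]c1=O` gives > 100000 nM in a functional assay on HeLa cells (Homo sapiens) for cytotoxicity, read by MTT assay, with a stated time of 72 h (on this read-out lower numbers stand for stronger inhibition and higher numbers for weaker inhibition), a limit of the assay rather than a number. Compound 2 `Nc1ccn(C/C=C\CNC(=O)c2ccccc2)c(=O)n1` also reaches only a limit, > 100000 nM. Compound 3 `Cc1cn(C/C=C\CNC(=O)c2ccc(F)cc2)c(=O)[nH]c1=O` likewise stops at a limit, > 100000 nM.

Compound 3 differs from compound 1 by fluoro in place of hydrogen on an aromatic carbon. The step that the two limits leave unreadable from compound 1 to compound 3 cannot be sized, since both ends sit at the limit of > 100000 nM in this assay, at which 3 of the 3 values shown sit. How the core of compound 2 differs from the core of compound 1 is not broken down here.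

Compound 4 `Nc1ccn(C/C=C\CNC(=O)c2ccc(F)cc2)c(=O)n1` has not been measured. Among the measured compounds shown here, it differs from compound 2 by fluoro in place of hydrogen on an aromatic carbon, the same change as the one from compound 1 to compound 3, at a place described in the same words. With every measured compound sitting at the limit of > 100000 nM in this assay, at which 3 of the 3 values shown sit, nothing in these data points to a change that the fluoro would bring into readable range. The step from compound 2 to compound 4 is therefore expected to be a step that the limit leaves unreadable from compound 2 to compound 4, which again cannot be read as a number. Compound 4 is estimated at 200000 nM, most likely reported as a limit once more, with a plausible range from 80000 nM to 1000000 nM.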

Compound 4, half-maximal inhibitory concentration: > 100000 nM
Compound 4: only a limit was reported (the forecaster's own chance of this, stated with the estimate: 90%); the middle value is on the limit's open side.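

In this assay compound 4 gives > 100000 nM as a limit and not a number. Compound 2 also stops at a limit, so the step between compound 2 and compound 4 cannot be read. The compounds shown leave open whether fluoro in place of hydrogen changes cytotoxicity on either core, since every result stops at the same point: the limit of > 100000 nM in this assay, at which 4 of the 4 values shown sit.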